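The compounds below may be only part of what the source reports. "The series", "measured", "known", "first", "only" and "open" are said of these compounds alone.

Measured so far:
Compound 1 `NCCCNc1c(C(=O)NCc2ccc(F)cc2)nc(Br)c2cccnc12`: 5000 nM
Compound 2 `N[C@H]1CC[C@H](Nc2c(C(=O)NCc3ccc(Cl)cc3Cl)nc(Br)c3cccnc23)CC1`: 5800 nM

In a functional assay on MDA-MB-435 cells (Homo sapiens) for cytotoxicity, read by MTT assay, with a stated time of 72 h (a higher number here means a weaker inhibitor, a lower number a stronger inhibitor), compound 2 gives 5800 nM, while compound 1 gives 5000 nM; the two numbers lie within the usual scatter of each other, so neither compound can be called the stronger. Compound 3 `N[C@H]1CC[C@H](Nc2c(C(=O)NCc3ccccc3)nc(Br)c3cccnc23)CC1` has not yet been measured. It differs from compound 2 in one place: phenyl in place of 2,4-dichlorophenyl on a saturated chain carbon bound to an amide-type nitrogen. For the measured compounds named here, no measured pair shows this kind of change, so its effect is not known from these data. A small weakening in this assay is expected, a step that would stay within the scatter, a 1.2-fold higher number from compound 2 to compound 3 (0.08 log units; within the scatter). Compound 3 is therefore estimated at about 7000 nM, with a range from 3000 nM to 18000 nM.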

Compound 3, half-maximal inhibitory concentration: 7000 nM
Estimate against measurement, compound 3: no gap at the digits printed, within the range that was stated.
By their numbers in this assay, from the lowest: compounds 1, 2 and 3 (each within the scatter of the next).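

In this assay, the step on replacing 2,4-dichlorophenyl with phenyl is a 1.2-fold higher number from compound 2 to compound 3 (0.08 log units; within the scatter) and no more. At this place, on a saturated chain carbon bound to an amide-type nitrogen, the two chlorine atoms therefore make no difference that this measurement can separate. No information is available to explain this result.

Still open, from the compounds shown here alone, is whether a methoxy group or a nitrile in place of the chlorine atoms, or a cyclohexyl group in place of the phenyl, would move the number beyond the scatter.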